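From methylsulfanyl to ethoxy on the shared core

The source may report more compounds than this note shows. Statements on the series, on what has been measured and on what is new or still open speak of the compounds shown alone.

Values in a functional assay on MCF7 cells (Homo sapiens) for inhibition, read by resazurin assay, with a stated time of 72 h; a higher number here means a weaker inhibitor, a lower number a stronger inhibitor:
- compound 1 `CCSc1ccc(C2C(Oc3ccccc3)C(=O)N2c2cc(OC)c(OC)c(OC)c2)cc1`: 210 nM
- compound 2 `CCOc1ccc(C2C(C3CC3)C(=O)N2c2cc(OC)c(OC)c(OC)c2)cc1`: 131 nM
- compound 3 `COc1cc(N2C(=O)C(Oc3ccccc3)C2c2ccc(SC)cc2)cc(OC)c1OC`: 152 nM

A lower number here marks a stronger inhibitor. Compound 3 holds the middle place of these three numbers, but its gaps to compound 1 and compound 2 both lie within the scatter, so that place carries little weight.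

The next compound is compound 4 `CCOc1ccc(C2C(Oc3ccccc3)C(=O)N2c2cc(OC)c(OC)c(OC)c2)cc1`, which has ethoxy in place of methylsulfanyl on an aromatic carbon, para to a large group: ethoxy in place of methylsulfanyl on an aromatic carbon.

Going by the values given here, no measured step makes this exact exchange. The nearest evidence is a 1.4-fold lower number from compound 1 to compound 3 (0.14 log units; within the scatter), where hydrogen stands in place of methyl on a saturated chain carbon bound to a sulfur. That step changes the same group position, and it stays small. Compound 2, at 131 nM, already carries ethoxy and differs from compound 4 at another place in the structure. Its number lies close to that of compound 3.

Together these give no reason to expect a real shift in this assay, in either direction. The expected change is a 1.1-fold lower number from compound 3 to compound 4 (0.04 log units; within the scatter), which would be no step beyond the scatter.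

For compound 4 the estimated value is 140 nM, with an expected range from 65 nM to 300 nM.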

Compound 4, half-maximal inhibitory concentration: 69 nM
Estimate against measurement, compound 4: 2.0-fold (0.31 log units) above; the range from low to high includes it.
By their numbers in this assay, from the lowest: compounds 4, 2, 3 and 1 (each within the scatter of the next, the first and the last beyond it).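

In this assay, going by these compounds alone, ethoxy in place of methylsulfanyl on the aromatic carbon gives a 2.2-fold lower number from compound 3 to compound 4 (0.34 log units; beyond the scatter), and ethoxy in place of ethylsulfanyl at the same place gives a 3.0-fold lower number from compound 1 to compound 4 (0.48 log units; beyond the scatter); the only earlier step at this position, a change within the sulfur-linked chain, stayed within the scatter, so these are the first steps here that go beyond it. At the other place that varies, phenoxy in place of cyclopropyl on a saturated ring carbon gives a 1.9-fold lower number from compound 2 to compound 4 (0.28 log units; within the scatter), which lies within the scatter, so the two groups at that place cannot be told apart in this assay while ethoxy sits on the aromatic ring. Nothing among the available measurements explains why the ethoxy compound gives a lower number than the two sulfur-linked compounds.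

On these data alone, it remains open whether a longer chain such as propoxy, or an amine, on that same aromatic carbon would keep the lower number seen with ethoxy. With only phenoxy and cyclopropyl shown at the saturated ring carbon, it is also open how a group such as a carboxylic acid would fare there.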